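The source may report more compounds than this note shows. Statements on the series, on what has been measured and on what is new or still open speak of the compounds shown alone.

Working notes on the series. The read-out is an ADME assay on HEK293 cells (Homo sapiens) for cytotoxicity, read by MTT assay, with a stated time of 36 h; on this read-out lower numbers stand for stronger inhibition and higher numbers for weaker inhibition.

Compound 3 `CC(C)(C)c1ccc(-c2nc(CN3CCC(C(=O)c4ccc5c(c4)OCCO5)CC3)co2)cc1` stands at a limit of the assay in this assay, giving > 150 ug/mL. Compound 1 `O=C(c1ccc2c(c1)OCCO2)C1CCN(Cc2coc(-c3ccc(F)cc3)n2)CC1` likewise sits at a limit in this assay, with > 150 ug/mL. Compound 2 `O=C(c1ccc2c(c1)OCCO2)C1CCN(Cc2coc(-c3ccc(Cl)cc3)n2)CC1` also sits at a limit in this assay, with > 150 ug/mL. All three values therefore share (the limit of > 150 ug/mL in this assay, at which 3 of the 3 values shown sit), and no ranking among compound 1, compound 2 and compound 3 can be drawn from them.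

The measured steps all concern a substituent on an aromatic carbon: a step that the two limits leave unreadable from compound 1 to compound 2, a step that the two limits leave unreadable from compound 1 to compound 3 and a step that the two limits leave unreadable from compound 2 to compound 3. None of them has a readable size, because each end of each step is a limit (the limit of > 150 ug/mL in this assay, at which 3 of the 3 values shown sit).

Compound 4 `O=C(c1ccc2c(c1)OCCO2)C1CCN(Cc2coc(-c3cccnc3)n2)CC1` differs from compound 3 by pyridin-3-yl in place of 4-(tert-butyl)phenyl on an aromatic carbon. The three unreadable steps bear on this change only in that they also swap the group on that same aromatic carbon without any of the values leaving the limit. Within the data shown here, no step of a readable size is available, so the expectation for compound 4 is that its value again falls at or beyond the limit, and the step of a number no higher from compound 3 to compound 4 (the limit leaves the size open) is expected to be none beyond the scatter. Compound 4 is thus estimated at 150 ug/mL in this assay, with a range from 75 ug/mL to 300 ug/mL.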

Compound 4, half-maximal inhibitory concentration: > 150 ug/mL
Compound 4: a limit, no number; the forecaster's own chance of this, stated with the estimate: 80%; the middle value lies on the limit itself.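

No step from compound 1, compound 2 or compound 3 to compound 4 can be read in this assay, because both ends of each step are limits and not numbers: the limit of > 150 ug/mL in this assay, at which 4 of the 4 values shown sit.

The compounds shown leave open how far each of the four lies beyond that limit, and whether any swap of the group on this aromatic carbon changes the value in this assay.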